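From pyridin-4-yl to furan-3-yl on a shared core

A few compounds are considered here, and "the series" means these few. Any claim that something is new, unique, unknown or untested is made for them only; others in the source may bear on it.

Compound 1 (`COc1cc2[nH]c(C)c(-c3ccncc3)c(=O)c2cc1Cl`) carries a pyridin-4-yl group on the shared core. In an ADME assay on J774 cells (Mus musculus) for cytotoxicity, with a stated time of 72 h (a higher number here means that more compound is needed for the effect, a lower number that less compound is needed), compound 1 gives > 33300 nM. This is a limit of the assay and not a number. In this assay, compound 2 (`COc1cc2[nH]c(C)c(-c3ccc(N4CCN(C)CC4)nc3)c(=O)c2cc1Cl`) gives > 25100 nM. This too is a limit. Going by the values given here, compound 1 therefore has no exact number, and no measured pair differs in only one place to offer a guide.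

Compound 3 (`COc1cc2[nH]c(C)c(-c3ccoc3)c(=O)c2cc1Cl`) has furan-3-yl in place of pyridin-4-yl on an aromatic carbon. No step beyond the usual scatter is expected in this assay. That expectation rests on compound 1 and its limit of > 33300 nM. The estimated change is an at least 1.1-fold lower number from compound 1 to compound 3 (0.04 log units; that floor lies within the scatter). For compound 3, the expected value is 30000 nM, with an estimated range from 13000 nM to 70000 nM.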

Compound 3, half-maximal effective concentration: > 34500 nM
Compound 3: only a limit was reported; the forecaster's own chance of this, stated with the estimate: 70%; middle value at least 1.1-fold (0.06 log units) from the limit.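

Going by these compounds alone, compound 1 and compound 3 are both reported only as limits of the assay, and no step between them can be read. Still open is the concentration at which any of these compounds reaches the half-maximal effect in this assay, and whether furan-3-yl in place of pyridin-4-yl changes it.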